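This account rests on a few compounds, and the source may have more. Where it says the series, first, only, none or still open, it means among the compounds named here.

Two cyclic peroxides carrying the same propanoic acid side chain were tested for their ability to slow the growth of a human lung tumour cell line. Compound 1, with the structure `C=C1CCC[C@H]2[C@](C)(CC[C@]3(C)CC[C@H]([C@@H](C)C(=O)O)OO3)[C@@H](C)CC[C@]12C`, has a fused ring system at the end of its chain. In a functional assay on HOP-62 cells (Homo sapiens) for inhibition (on this read-out lower numbers stand for stronger inhibition of growth and higher numbers for weaker inhibition of growth), compound 1 gives 1050 nM. Compound 2, with the structure `CC1=C(CC/C(C)=C/CC[C@@]2(C)CC[C@@H]([C@H](C)C(=O)O)OO2)C(C)(C)CCC1`, carries a single ring with an open alkene chain in its place. In this assay compound 2 gives only > 100000 nM, which is a limit of the assay rather than a number. That outcome is recorded as the limit of > 100000 nM in this assay, at which 1 of the 2 values shown sits.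

Compound 3, with the structure `CC1=C(CC/C(C)=C/CC[C@@]2(C)CC[C@H]([C@H](C)C(=O)O)OO2)C(C)(C)CCC1`, is the not yet measured partner of compound 2. The difference between them is the two compounds have the same atoms and bonds and differ only in configuration as drawn: 1 of 4 stereo elements differ; a stereocentre at a saturated ring carbon is drawn S in compound 2 and R in compound 3. Among the compounds with values here, no pair of measured compounds that differs in a single place is available to show how large such a change can be. Because compound 2 stands at the limit (the limit of > 100000 nM in this assay, at which 1 of the 2 values shown sits), the same result is expected for compound 3, with the step from compound 2 to compound 3 estimated at a number no higher from compound 2 to compound 3 (the limit leaves the size open). The estimate for compound 3 in this assay is 100000 nM, expected to fall between 20000 nM and 300000 nM.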

Compound 3, concentration for 50% growth inhibition: > 5000 nM
Compound 3: no number, only a limit (the forecaster's own chance of this, stated with the estimate: 65%); the middle value does not contradict the limit.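

In this assay, within the data shown here, compound 2 and compound 3 each give only a limit of the assay and not a number, so no step between the two can be read. The compounds shown leave open whether changing the configuration at this one saturated ring carbon alters growth inhibition at all, and by how much.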